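Swapping an acetamido for an acetoxy on the sugar ring

This account rests on a few compounds, and the source may have more. Where it says the series, first, only, none or still open, it means among the compounds named here.

Measured so far:
- compound 1, `CO[C@@H]1O[C@H](CNC(=S)NCCN([C@@H](C(=O)O)C(C)C)S(=O)(=O)c2ccc(-c3ccccc3)cc2)[C@@H](OC(C)=O)[C@H](OC(C)=O)[C@H]1OC(C)=O`: 32 nM
- compound 2, `CO[C@@H]1O[C@H](CN([C@@H](C(=O)O)C(C)C)S(=O)(=O)c2ccc(-c3ccccc3)cc2)[C@@H](OC(C)=O)[C@H](OC(C)=O)[C@H]1NC(C)=O`: 1240 nM

Both compounds were tested in an assay on isolated protein for inhibition of matrix metalloproteinase-9 (Homo sapiens), read by fluorescence, with stated times of 3 h, 10 s and 15 min; a higher number here means a weaker inhibitor, a lower number a stronger inhibitor. Compound 1 gives 32 nM, while compound 2 gives 1240 nM, the highest of the two numbers and a weaker inhibitor than compound 1 by a margin well beyond the usual scatter. The two compounds differ in more than one place, so only their two values can be compared, not a single change.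

Compound 3, `CO[C@@H]1O[C@H](CN([C@@H](C(=O)O)C(C)C)S(=O)(=O)c2ccc(-c3ccccc3)cc2)[C@@H](OC(C)=O)[C@H](OC(C)=O)[C@H]1OC(C)=O`, is the next compound and has not yet been measured. It differs from compound 2 in one place: acetoxy in place of acetamido on a saturated ring carbon. Put simply, an acetoxy replaces an acetamido on a saturated ring carbon of the shared core, with everything else unchanged. For the measured compounds named here, no measured pair isolates this swap, so its effect cannot be read from the data. The expectation is a step of modest size, if any, from compound 2 to compound 3, likely toward a somewhat lower number but possibly within the scatter, a 1.8-fold lower number from compound 2 to compound 3 (0.25 log units; within the scatter). Compound 3 is therefore estimated at 700 nM, with a range from 200 nM to 2500 nM.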

Compound 3, half-maximal inhibitory concentration: 2600 nM
Compound 3: middle estimate off by 3.7-fold (0.57 log units), on the low side; the whole stated range lies below it.
By their numbers in this assay, from the lowest: compound 1; then compound 2; then compound 3.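

In this assay, this saturated ring carbon now has a change measured on its own: acetoxy in place of acetamido gives a 2.1-fold higher number from compound 2 to compound 3 (0.32 log units; beyond the scatter), a modest step but one beyond the usual scatter. The earlier pair differed in more than one place and could not show this, whereas here the rest of the structure stays the same, so the difference can be assigned to this one swap, with the acetamido-bearing compound 2 the stronger inhibitor of the two. The two groups have the same number of heavy atoms, but the acetamido has 1 hydrogen-bond donor and 1 acceptor, while the acetoxy has 0 donors and 2 acceptors, and no available measurement shows what lies behind the step.

Going by these compounds, it remains open whether a hydroxyl or an amine on this carbon would give a number closer to that of compound 2 or compound 3, and whether an acyl group with a longer chain would shift it further. It is also unknown whether the same swap would have a similar effect on the core of compound 1, which gives 32 nM.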